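Replacing the Ring Group of Compound 2

The source may hold more compounds than are shown below. What is called first, only, known or untested is meant among the compounds shown, and "the series" means these compounds.

Measured values in a functional assay on A2780 cells (Homo sapiens) for antiproliferative activity, read by MTT assay, with a stated time of 72 h (a lower number here means a stronger inhibitor of growth, a higher number a weaker inhibitor of growth), are these
Compound 1 `COc1cc(OC)c(/C=C/S(=O)(=O)Cc2cnc(Cl)cn2)c(OC)c1` gives 4760 nM
Compound 2 `CCOc1cnc(CS(=O)(=O)/C=C/c2c(OC)cc(OC)cc2OC)cn1` gives 540 nM
Compound 3 `COc1cc(OC)c(/C=C/S(=O)(=O)Nc2cnc(Cl)cn2)c(OC)c1` gives > 10000 nM as a limit of the assay

Compound 2 has the lower of the two true numbers, while compound 3 gives only a limit. Compound 4 `COc1cc(OC)c(/C=C/S(=O)(=O)Cc2nc(N)ncc2OC)c(OC)c1` carries 2-amino-5-methoxypyrimidin-4-yl in place of 5-ethoxypyrazin-2-yl on a saturated chain carbon bound to a sulfonyl sulfur. Among the compounds with values here, two measured steps bear on this only indirectly. Changing one ring group gave a clear shift (an 8.8-fold lower number from compound 1 to compound 2 (0.95 log units; beyond the scatter)), so such changes can matter. The other step (an at least 2.1-fold higher number from compound 1 to compound 3 (0.32 log units; beyond the scatter)) altered the link at the sulfonyl sulfur, which compound 4 keeps as in compound 2. Neither fixes a direction in this assay for this swap. The expected change is small but uncertain (a 1.3-fold higher number from compound 2 to compound 4 (0.11 log units; within the scatter)). For compound 4 the estimated value is 700 nM (expected range 90 nM to 5000 nM).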

Compound 4, concentration for 50% growth inhibition: > 10000 nM
Compound 4: only a limit was reported (the forecaster's own chance of this, stated with the estimate: 10%); middle value at least 14-fold (1.15 log units) away from the limit.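

On a saturated chain carbon bound to a sulfonyl sulfur, the ring group can decide growth inhibition in this assay: 2-amino-5-methoxypyrimidin-4-yl in place of 5-ethoxypyrazin-2-yl costs heavily (an at least 18-fold higher number from compound 2 to compound 4 (1.26 log units; beyond the scatter)). It also falls short of 5-chloropyrazin-2-yl (an at least 2.1-fold higher number from compound 1 to compound 4 (0.32 log units; beyond the scatter)). Compound 4 gives only a limit, so both steps are minimum sizes: the limit of > 10000 nM in this assay, at which 2 of the 4 values shown sit.

Going by these compounds, compound 4 alters the ring, the amino group and the ether together, so which change matters stays open. A pyrazine carrying an amine, or a propoxy group in place of ethoxy, would help separate them.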